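The source may report more compounds than this note shows. Statements on the series, on what has been measured and on what is new or still open speak of the compounds shown alone.

Measured compounds in a functional assay on HEK293 cells with D(4) dopamine receptor (Homo sapiens) as the target, read by FLIPR; on this read-out higher numbers stand for larger maximal responses and lower numbers for smaller maximal responses:
compound 1 `CO/N=C(\c1ccc(Cl)cc1)C(O)CN1CCN(c2ccccn2)CC1` gives 89%
compound 2 `CO/N=C(\c1ccc(Cl)cc1)C(CN1CCN(c2ccccn2)CC1)OC` gives 79%
compound 3 `Cc1cccc(/C(=N\O)C(O)CN2CCN(c3ccccn3)CC2)c1` gives 66%

Compound 2 is derived from compound 1 by methyl in place of hydrogen on an oxygen on a saturated carbon; the step is a number 10 percentage points lower from compound 1 to compound 2 (within the scatter). Compound 3 carries a different core; the difference between the cores of compound 1 and compound 3 is not broken down here. Compound 3 stands lowest of the three measured values, beyond the scatter from both compound 2 and compound 1.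

Compound 4 `COC(CN1CCN(c2ccccn2)CC1)/C(=N/O)c1cccc(C)c1` is not yet measured. It is derived from compound 3 by methyl in place of hydrogen on an oxygen on a saturated carbon, the same change as from compound 1 to compound 2 at the same place. Among the measured compounds shown here, for compound 4 in this assay the expected step is a number 8 percentage points lower from compound 3 to compound 4 (within the scatter), resting on the single earlier instance a number 10 percentage points lower from compound 1 to compound 2 (within the scatter). The estimate for compound 4 is 58%, expected to fall between 45% and 72%.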

Compound 4, largest response reached (reported as efficacy), in percent of the reference or control that the assay uses: 53%
Estimate against measurement, compound 4: 5 percentage points above; the measured number falls inside the stated range.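

In this assay, hydroxy to methoxy gives a number 13 percentage points lower from compound 3 to compound 4 (beyond the scatter), a modest step. Across the two cores, the size of the step carries over without a difference that can be told from the scatter: the same change on two cores in this assay, a number 10 percentage points lower (within the scatter) from compound 1 to compound 2 and a number 13 percentage points lower (beyond the scatter) from compound 3 to compound 4, 3 percentage points apart, within the scatter of two such steps. This rests on two pairs only, and just the newer step stands clear of the scatter; it gives no general rule for other cores and no reason for the lower response.

The compounds shown leave open whether ethoxy, with its longer chain, or an amine at the same place would give a comparable step. Going by these compounds, how either group would behave on each of the two cores also remains open.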